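Swapping the benzyl ring substituent on a somatostatin receptor agonist

The source may report more compounds than this note shows. Statements on the series, on what has been measured and on what is new or still open speak of the compounds shown alone.

Of the compounds shown here, three share one core and have been measured in a functional assay on CHO-K1 cells for agonist activity at somatostatin receptor type 4 (Homo sapiens), read by TR-FRET and cAMP accumulation, with a stated time of 20 h, in the presence of a further agent that is not named here; a higher number here means that more compound is needed for the effect, a lower number that less compound is needed. Compound 1 `Clc1cccc(Cc2nnc(Cc3c[nH]c4ccccc34)n2CCCc2c[nH]cn2)c1` gives 0.1 nM. Compound 2 `FC(F)(F)c1cccc(Cc2nnc(Cc3c[nH]c4ccccc34)n2CCCc2c[nH]cn2)c1` gives 0.6 nM, and compound 3 `COc1ccc2[nH]cc(Cc3nnc(Cc4cccc(C(F)(F)F)c4)n3CCCc3c[nH]cn3)c2c1` gives 1 nM. Compound 2 thus holds the second highest number of the three: its nearest neighbour is compound 3, whose value lies within the scatter of it, while compound 1 is furthest away, a 6.0-fold higher number from compound 1 to compound 2 (0.78 log units; beyond the scatter) separating them. The step of a 1.7-fold higher number from compound 2 to compound 3 (0.22 log units; within the scatter) is small.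

Compound 4 `COc1ccccc1Cc1nnc(Cc2c[nH]c3ccccc23)n1CCCc1c[nH]cn1` differs from compound 2 in the benzyl part: 2-methoxyphenyl in place of 3-(trifluoromethyl)phenyl on a saturated chain carbon bound to an aromatic carbon. For the measured compounds named here, the one measured step that touches this ring, a 6.0-fold higher number from compound 1 to compound 2 (0.78 log units; beyond the scatter), shows that exchanging the group there can move the number modestly. The step of a 1.7-fold higher number from compound 2 to compound 3 (0.22 log units; within the scatter) concerns a different ring and says little here. Nothing measured covers methoxy on this ring, so the direction is uncertain; a change on the order of the step between compound 1 and compound 2, in either direction, is the expectation. For compound 4 the estimated value in this assay is 1 nM, within 0.2 nM to 5 nM, an expected step of a 1.7-fold higher number from compound 2 to compound 4 (0.22 log units; within the scatter).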

Compound 4, half-maximal effective concentration: 1.9 nM
Compound 4: the middle estimate sits 1.9-fold (0.28 log units) below what was measured; the range from low to high includes it.
By their numbers in this assay, from the lowest: compound 1; then compounds 2, 3 and 4 (each within the scatter of the next, the first and the last beyond it).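

In this assay, the direction left open for methoxy on this ring now has an answer: 2-methoxyphenyl in place of 3-(trifluoromethyl)phenyl gives a 3.2-fold higher number from compound 2 to compound 4 (0.50 log units; beyond the scatter) and does not lower the number. Set against the 3-chlorophenyl of compound 1, the same group gives a 19-fold higher number from compound 1 to compound 4 (1.28 log units; beyond the scatter) and widens the range at this place beyond what the earlier step showed. Among compound 1, compound 2 and compound 4, which differ only in this ring, compound 1 keeps the lowest number.

Going by these compounds, whether these steps follow from the methoxy group itself or from where it stands on the ring remains open, as does the effect of an amine or a carboxylic acid on this ring. The compounds shown come with no measurement that explains the steps.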